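Sulfonyl aryl exchange carried onto the second core

A few compounds are considered here, and "the series" means these few. Any claim that something is new, unique, unknown or untested is made for them only; others in the source may bear on it.

Compound 1 `CC(O)(CS(=O)(=O)c1ccccc1C(F)(F)F)C(=O)Nc1ccc(S(F)(F)(F)(F)F)cc1` and compound 2 `CC(O)(CS(=O)(=O)c1ccc(OC(F)(F)F)cc1)C(=O)Nc1ccc(S(F)(F)(F)(F)F)cc1` share one core; compound 3 `CC(O)(CS(=O)(=O)c1ccccc1C(F)(F)F)C(=O)Nc1cccc(S(F)(F)(F)(F)F)c1` and compound 4 `CC(O)(CS(=O)(=O)c1ccc(OC(F)(F)F)cc1)C(=O)Nc1cccc(S(F)(F)(F)(F)F)c1` share another. The difference between the two cores is not broken down here. In a functional assay on VCaP cells (Homo sapiens) for antiproliferative activity, read by propidium iodide staining, with a stated time of 96 h (on this read-out higher numbers stand for weaker inhibition and lower numbers for stronger inhibition), compound 1 gives 23800 nM, compound 2 gives 95800 nM and compound 3 gives 40800 nM; compound 3 lies within the scatter of compound 1 and beyond it from compound 2. On the first core the change 4-(trifluoromethoxy)phenyl in place of 2-(trifluoromethyl)phenyl on a sulfonyl sulfur made a 4.0-fold higher number from compound 1 to compound 2 (0.60 log units; beyond the scatter). Compound 4 carries the same change on the second core, (4-(trifluoromethoxy)phenyl in place of 2-(trifluoromethyl)phenyl on a sulfonyl sulfur), at the same place. For compound 4 the expected step in this assay is a 3.9-fold higher number from compound 3 to compound 4 (0.59 log units; beyond the scatter), because the earlier step of a 4.0-fold higher number from compound 1 to compound 2 (0.60 log units; beyond the scatter) came from this very change. Compound 4 is therefore estimated at 160000 nM, with a range from 60000 nM to 400000 nM.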

Compound 4, half-maximal inhibitory concentration: 15100 nM
Beside the measured number, compound 4's estimate is 11-fold (1.03 log units) above it; the measured number lies below the stated range.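

On the core of compound 3, in this assay, the change gave a 2.7-fold lower number from compound 3 to compound 4 (0.43 log units; beyond the scatter). Set beside the step on the core of compound 1, the change runs in the opposite direction, so in this series its effect cannot be carried from one core to the other: the same change on two cores in this assay, a 4.0-fold higher number (0.60 log units; beyond the scatter) from compound 1 to compound 2 and a 2.7-fold lower number (0.43 log units; beyond the scatter) from compound 3 to compound 4, 11-fold (1.04 log units) apart, beyond the scatter of two such steps

This rests on one pair per core and does not show which difference between the cores lies behind the reversal.

Open, on these data alone, is whether the reversal extends to other aryl groups on the sulfonyl sulfur. A phenyl carrying a nitrile or an amine, for instance, might follow either core.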